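The source may report more compounds than this note shows. Statements on the series, on what has been measured and on what is new or still open speak of the compounds shown alone.

Series notes. The three measured analogues share one core and differ only in the aryl group on the carbon with a double bond to nitrogen. Compound 1 `CN(C)CCn1cnnc1-c1cc(Oc2ccc(NC(=O)N/N=C/c3ccc(Cl)cc3Cl)cc2F)ccn1` gives 390 nM in a functional assay on HT-29 cells (Homo sapiens) for cytotoxicity, read by MTT assay, with a stated time of 72 h; on this read-out lower numbers stand for stronger inhibition and higher numbers for weaker inhibition. Compound 2 `CN(C)CCn1cnnc1-c1cc(Oc2ccc(NC(=O)N/N=C/c3c[nH]c4ccccc34)cc2F)ccn1` gives 1300 nM in this assay, and compound 3 `CN(C)CCn1cnnc1-c1cc(Oc2ccc(NC(=O)N/N=C/c3ccc(F)cc3)cc2F)ccn1` gives 1370 nM in this assay. Compound 3 and compound 2 sit within the scatter of each other; the steps beyond the scatter are a 3.3-fold higher number from compound 1 to compound 2 (0.52 log units; beyond the scatter) and a 3.5-fold higher number from compound 1 to compound 3 (0.55 log units; beyond the scatter).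

Compound 4 `CN(C)CCn1cnnc1-c1cc(Oc2ccc(NC(=O)N/N=C/c3ccc(F)cc3F)cc2F)ccn1` has not been measured. The change from compound 3 is fluoro in place of hydrogen on an aromatic carbon: the fluoro enters on an aromatic carbon of the six-membered aromatic ring of carbon only, ortho to a large group and meta to the fluoro group already present, so the ring reads 2,4-difluorophenyl in place of 4-fluorophenyl. Going by the values given here, the step that bears on it is the one between compound 1 and compound 3, where the 2,4-dichlorophenyl ring carried the lower number, a 3.5-fold higher number from compound 1 to compound 3 (0.55 log units; beyond the scatter) read in reverse. Among the compounds with values here, the second halogen in compound 4 is fluorine rather than chlorine, and no measured pair isolates that, so only part of that gain is expected. For compound 4 the estimate in this assay is 800 nM, with a range from 300 nM to 2000 nM, corresponding to an expected 1.7-fold lower number from compound 3 to compound 4 (0.23 log units; within the scatter).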

Compound 4, half-maximal inhibitory concentration: 960 nM
For compound 4 the middle estimate is 1.2-fold (0.08 log units) below the measured one; low and high end bracket the measured number.
By their numbers in this assay, from the lowest: compound 1; then compounds 4, 2 and 3 (each within the scatter of the next).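

Adding a fluoro on an aromatic carbon of the six-membered aromatic ring, ortho to a large group and meta to the fluoro group already present, leaves compound 4 within the scatter of compound 3 in this assay (a 1.4-fold lower number from compound 3 to compound 4 (0.15 log units; within the scatter)), so a second fluoro on this ring gives no readable change. Going by these compounds alone, compound 4 also stays within the scatter of the indole analogue (a 1.4-fold lower number from compound 2 to compound 4 (0.13 log units; within the scatter)), while the exchange of 2,4-dichlorophenyl for 2,4-difluorophenyl, with the substitution pattern held constant, gives a step beyond the scatter (a 2.5-fold higher number from compound 1 to compound 4 (0.39 log units; beyond the scatter)); this is the first pair to isolate the identity of the halogen, and it separates compound 1 from compound 4, though a pattern cannot be claimed from this one pair. Nothing measured here accounts for this difference between the two halogens.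

The compounds shown leave open which of the two chlorines in compound 1 carries the step, a question that 2-chloro-4-fluorophenyl and 4-chloro-2-fluorophenyl would separate. Also open, on these data alone, is how this ring responds to substituents other than halogens, such as methoxy, trifluoromethyl or an amine.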